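Benzoyl for hydroxyalkyl on the shared core

The compounds below may be only part of what the source reports. "The series", "measured", "known", "first", "only" and "open" are said of these compounds alone.

Compound 3 `C[C@H](CS[C@@H](CCc1ccccc1CC(C)(C)O)c1cccc(/C=C/c2ccc3ccc(Cl)cc3n2)c1)C(=O)O` gives 1 nM in an assay on membranes from lung for inhibition of cysteinyl leukotriene receptor 1 (Cavia porcellus) (on this read-out higher numbers stand for weaker inhibition and lower numbers for stronger inhibition), the lowest of the three numbers: compound 1 `CC(=O)c1ccccc1CC[C@H](SC[C@@H](C)C(=O)O)c1cccc(/C=C/c2ccc3ccc(Cl)cc3n2)c1` gives 3 nM and compound 2 `CCC(=O)c1ccccc1CC[C@H](SC[C@@H](C)C(=O)O)c1cccc(/C=C/c2ccc3ccc(Cl)cc3n2)c1` gives 3.7 nM, so a 3.0-fold lower number from compound 1 to compound 3 (0.48 log units; beyond the scatter) and a 3.7-fold lower number from compound 2 to compound 3 (0.57 log units; beyond the scatter), both modest but beyond the scatter, while a 1.2-fold higher number from compound 1 to compound 2 (0.09 log units; within the scatter). Compound 4 `C[C@H](CS[C@@H](CCc1ccccc1C(=O)c1ccccc1)c1cccc(/C=C/c2ccc3ccc(Cl)cc3n2)c1)C(=O)O` carries benzoyl in place of 2-hydroxy-2-methylpropyl on an aromatic carbon. The step reverses the direction of the two earlier ketone-to-hydroxyalkyl steps, so a modest rise in this assay is expected for compound 4, roughly to the level of compound 1 and compound 2, with some room for a larger number given the added ring. Compound 4 is therefore estimated at 5 nM (range 2 nM to 13 nM), that is a 5.0-fold higher number from compound 3 to compound 4 (0.70 log units; beyond the scatter).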

Compound 4, half-maximal inhibitory concentration: 4.3 nM
Beside the measured number, compound 4's estimate is 1.2-fold (0.07 log units) above it; the measured number falls inside the stated range.
By their numbers in this assay, from the lowest: compound 3; then compounds 1, 2 and 4 (each within the scatter of the next).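

In this assay, phenyl on the carbonyl carbon reads no differently from ethyl (a 1.2-fold higher number from compound 2 to compound 4 (0.07 log units; within the scatter)) or methyl (a 1.4-fold higher number from compound 1 to compound 4 (0.16 log units; within the scatter)), both steps within the scatter, so this place tolerates an added aromatic ring on the ketone. The 2-hydroxy-2-methylpropyl group of compound 3 also stays apart from this third ketone (a 4.3-fold higher number from compound 3 to compound 4 (0.63 log units; beyond the scatter)), and the separation now holds across acetyl, propanoyl and benzoyl. No measurement here accounts for that separation. Open, going by these compounds, is whether the hydroxyl or the two methyl groups carry it, which a 2-hydroxyethyl group or an amine at this place would test.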